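One swap, measured once, expected again on a fluorinated core

A few compounds are considered here, and "the series" means these few. Any claim that something is new, unique, unknown or untested is made for them only; others in the source may bear on it.

The series was tested in a functional assay on MCF7 cells (Homo sapiens) for antiproliferative activity, read by MTT assay, with a stated time of 72 h; on this read-out higher numbers stand for weaker inhibition and lower numbers for stronger inhibition. Compound 1 `Cc1cccc(NC2=C/C(=N/NC(N)=S)C(=O)N=C2Nc2cccc(C)c2)c1` gives 150 nM. Compound 3 `Cc1cccc(NC2=C/C(=N/N=C(\N)SCc3ccccc3)C(=O)N=C2Nc2cccc(C)c2)c1` keeps the core of compound 1 but carries the change (a group of 11 heavy atoms (8 carbon, 2 nitrogen, 1 sulfur; one six-membered aromatic ring of carbon only) in place of a group of 4 heavy atoms (1 carbon, 2 nitrogen, 1 sulfur; no ring), on a double-bonded nitrogen). In this assay compound 3 gives 9340 nM, so that this single swap made the step of a 62-fold higher number from compound 1 to compound 3 (1.79 log units; beyond the scatter).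

Compound 2 `NC(=S)N/N=C1/C=C(Nc2ccc(F)cc2)C(Nc2ccc(F)cc2)=NC1=O` stands on a different core; how that core differs from the core of compound 1 is not broken down here. In this assay compound 2 gives 1120 nM, which places it between the other two measured compounds, with steps to each of them that lie beyond the scatter.

Compound 4 `N/C(=N\N=C1\C=C(Nc2ccc(F)cc2)C(Nc2ccc(F)cc2)=NC1=O)SCc1ccccc1` has not been measured. It differs from compound 2 by a group of 11 heavy atoms (8 carbon, 2 nitrogen, 1 sulfur; one six-membered aromatic ring of carbon only) in place of a group of 4 heavy atoms (1 carbon, 2 nitrogen, 1 sulfur; no ring), on a double-bonded nitrogen, and since the place is described in the same words for both pairs, this is the same change that was made from compound 1 to compound 3. For the measured compounds named here, with only that one measured instance as a guide, the account expects the step from compound 2 to compound 4 to be a 36-fold higher number from compound 2 to compound 4 (1.55 log units; beyond the scatter), resting on the measured step of a 62-fold higher number from compound 1 to compound 3 (1.79 log units; beyond the scatter) and allowing for the possibility that the new core responds somewhat differently. On that basis compound 4 is estimated to give about 40000 nM in this assay, with a range expected from 8000 nM to 150000 nM.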

Compound 4, half-maximal inhibitory concentration: 7580 nM
Estimate against measurement, compound 4: 5.3-fold (0.72 log units) above; the whole stated range lies above it.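

In this assay the swap raised the number on the second core as well, the new step being a 6.8-fold higher number from compound 2 to compound 4 (0.83 log units; beyond the scatter), so the direction of the change carried over from one core to the other. Its size did not carry over: the same change on two cores in this assay, a 62-fold higher number (1.79 log units; beyond the scatter) from compound 1 to compound 3 and a 6.8-fold higher number (0.83 log units; beyond the scatter) from compound 2 to compound 4, 9.2-fold (0.96 log units) apart, beyond the scatter of two such steps. With a single pair on each core, this shows that the same swap weakened inhibition on both cores by different amounts, but it does not show which feature of the core of compound 2 goes with the smaller step, nor how a third core would respond.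

The compounds shown leave open how the step would run if the entering group carried a methyl or an ethyl chain instead of its six-membered aromatic ring, and so whether that ring has any bearing on the size of the step. They also leave open how the swap would fare on a core carrying chlorine or a methoxy group in place of the fluorine of compound 2.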